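Swapping Trifluoromethyl for Fluoro: What to Expect of Compound 4

This account rests on a few compounds, and the source may have more. Where it says the series, first, only, none or still open, it means among the compounds named here.

Measured so far in an ADME assay on Vero cells (Chlorocebus sabaeus) for cytotoxicity, with a stated time of 72 h; a lower number here means a stronger inhibitor, a higher number a weaker inhibitor:
Compound 1, `O=[N+]([O-])c1cn2c(n1)OC[C@@H](OCc1cc(-c3ccc(C(F)(F)F)cc3)no1)C2`, gives only a limit, > 128000 nM.
Compound 2, `O=[N+]([O-])c1cn2c(n1)OC[C@@H](OCc1cc(-c3ccc(F)cc3)no1)C2`, gives only a limit, > 128000 nM.
Compound 3, `O=[N+]([O-])c1cn2c(n1)OC[C@@H](OCc1nnn(-c3ccc(C(F)(F)F)cc3)n1)C2`, gives only a limit, > 128000 nM.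

Compound 1 and compound 2 share one core and differ in a single place: fluoro in place of trifluoromethyl on an aromatic carbon. Because both readings are limits rather than numbers, the step that the two limits leave unreadable from compound 1 to compound 2 cannot be sized; this follows from the limit of > 128000 nM in this assay, at which 3 of the 3 values shown sit.

Compound 3 has a different core from compound 1; how the two cores differ is not broken down here. Compound 4, `O=[N+]([O-])c1cn2c(n1)OC[C@@H](OCc1nnn(-c3ccc(F)cc3)n1)C2`, is the not yet measured partner of compound 3, and it differs from compound 3 by fluoro in place of trifluoromethyl on an aromatic carbon. Within the data shown here, this is the same change as the one between compound 1 and compound 2, made at the same kind of place.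

Since that change left compound 1 and compound 2 both at the limit, compound 4 is expected to follow compound 3 with an estimated step that the limit leaves unreadable from compound 3 to compound 4. Compound 4 is therefore estimated at 150000 nM in this assay, with a range from 100000 nM to 300000 nM, most likely reported again as a limit.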

Compound 4, half-maximal inhibitory concentration: > 128000 nM
Compound 4: no number, only a limit; the forecaster's own chance of this, stated with the estimate: 85%; the middle value is on the limit's open side.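

In this assay compound 3 and compound 4 each give only a limit, so no size can be read for the step between them: the limit of > 128000 nM in this assay, at which 4 of the 4 values shown sit.

Still open, as far as these compounds go, is whether fluoro in place of trifluoromethyl changes this read-out at all, and at what concentration, if any, these four compounds would reach half-maximal inhibition.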